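Aryl in place of chloro: compound 3 to compound 4

A few compounds are considered here, and "the series" means these few. Any claim that something is new, unique, unknown or untested is made for them only; others in the source may bear on it.

Three compounds share a core and differ at one aromatic carbon. Compound 1 `CC(C(=O)NCc1ccc(C(F)(F)F)cc1N1CCC(C)(C)CC1)c1ccc(NS(C)(=O)=O)c(F)c1` gives 1.3 nM in an assay on CHO cells for antagonist activity at transient receptor potential cation channel subfamily V member 1 (Homo sapiens), read by FLIPR; on this read-out higher numbers stand for weaker inhibition and lower numbers for stronger inhibition. Compound 2 `CC(C(=O)NCc1ccc(C(F)(F)F)cc1SCc1ccco1)c1ccc(NS(C)(=O)=O)c(F)c1` gives 3.2 nM in this assay, and compound 3 `CC(C(=O)NCc1ccc(C(F)(F)F)cc1Cl)c1ccc(NS(C)(=O)=O)c(F)c1` gives 4 nM in this assay. Compound 3 stands at the highest of the three numbers; its gap to compound 2 is within the scatter (a 1.3-fold higher number from compound 2 to compound 3 (0.10 log units; within the scatter)), while its gap to compound 1 is beyond it (a 3.1-fold higher number from compound 1 to compound 3 (0.49 log units; beyond the scatter)).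

Compound 4 `CC(C(=O)NCc1ccc(C(F)(F)F)cc1-c1ccc(F)c(Cl)c1)c1ccc(NS(C)(=O)=O)c(F)c1` awaits measurement in this assay. It differs from compound 3 by 3-chloro-4-fluorophenyl in place of chloro on an aromatic carbon. Both measured steps that end at compound 3 bear on this position: a larger group there gave a lower number in one case (a 3.1-fold higher number from compound 1 to compound 3 (0.49 log units; beyond the scatter)) and a number within the scatter in the other (a 1.3-fold higher number from compound 2 to compound 3 (0.10 log units; within the scatter)). Neither change matches the entering group, so the expectation rests on a loose reading of these two steps: a modest lowering in this assay, or no step beyond the scatter. Compound 4 is expected at 2.5 nM, with a range of 0.8 nM to 8 nM. The step this implies, a 1.6-fold lower number from compound 3 to compound 4 (0.20 log units; within the scatter), is expected to be modest and may fall within the scatter.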

Compound 4, inhibition constant: 0.6 nM
Beside the measured number, compound 4's estimate is 4.2-fold (0.62 log units) above it, and the stated range ends above it.
By their numbers in this assay, from the lowest: compound 4; then compound 1; then compounds 2 and 3 (each within the scatter of the next).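

In this assay, among the compounds shown here, 3-chloro-4-fluorophenyl in place of chloro gives a 6.7-fold lower number from compound 3 to compound 4 (0.82 log units; beyond the scatter) and shows that this aromatic carbon accepts an aromatic ring attached directly, a kind of group absent from the earlier compounds. The same group also improves on both larger groups shown, with a 5.3-fold lower number from compound 2 to compound 4 (0.73 log units; beyond the scatter) against ((furan-2-yl)methyl)sulfanyl and a 2.2-fold lower number from compound 1 to compound 4 (0.34 log units; beyond the scatter) against 4,4-dimethylpiperidin-1-yl, so compound 4 now holds the lowest number of the four and the position has more room for gain than the first three compounds indicated. Nothing in the data accounts for the size of these steps.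

The compounds shown do not separate the contribution of the phenyl ring itself from that of its chloro and fluoro substituents, a question that unsubstituted phenyl, 4-fluorophenyl and 3-chlorophenyl at this carbon would address. Also open is how this position responds to a pyridine ring, or to a phenyl ring carrying an amine or a carboxylic acid, since every group shown here other than the piperidine is without a basic or acidic centre in its name.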